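The source may report more compounds than this note shows. Statements on the series, on what has been measured and on what is new or still open speak of the compounds shown alone.

Working notes on the series. The shared core carries a piperazine-linked side chain whose terminal nitrogen varies. Compound 1 `CC(=O)N(CC(C1CCCCC1)N1CCN(C(=O)[C@@H]2CN(C(C)(C)C)C[C@H]2c2ccc(F)cc2F)CC1)C(C)C` and compound 2 `CC(C)N(CC(C1CCCCC1)N1CCN(C(=O)[C@@H]2CN(C(C)(C)C)C[C@H]2c2ccc(F)cc2F)CC1)C(=O)c1cccnn1` carry an amide at that nitrogen; in an assay on CHO cells for displacement of a labelled ligand from Melanocortin receptor 4 (Homo sapiens) (on this read-out higher numbers stand for weaker inhibition and lower numbers for stronger inhibition), compound 1 gives 28 nM; 29 nM (2 entries) and compound 2 gives 64 nM; 18 nM (2 entries), each from repeated entries (the several entries of compound 1 in this assay, 28 nM; 29 nM (2 entries); (the several entries of compound 2 in this assay, 64 nM; 18 nM (2 entries))). Compound 3 `CC(C)CN(CC(C)C)CC(C1CCCCC1)N1CCN(C(=O)[C@@H]2CN(C(C)(C)C)C[C@H]2c2ccc(F)cc2F)CC1` carries a tertiary amine instead; in this assay compound 3 gives 1900 nM, the only number shown for it, and two further entries carry no single number. That number stands well above the numbers of compound 1 and compound 2.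

Compound 4 `CC(C)NCC(C1CCCCC1)N1CCN(C(=O)[C@@H]2CN(C(C)(C)C)C[C@H]2c2ccc(F)cc2F)CC1` is the next step: isopropylamino in place of diisobutylamino on a saturated chain carbon, two bonds along the chain from an amine nitrogen in a ring and a saturated ring carbon. For the measured compounds named here, no measured step between two compounds that differ in one place is available to set the size. The expectation is that compound 4 moves toward the numbers of compound 1 and compound 2 without reaching them, with the estimated step from compound 3 to compound 4 in this assay being a 9.5-fold lower number from compound 3 to compound 4 (0.98 log units; beyond the scatter), well beyond the scatter. For compound 4 in this assay the estimate is 200 nM, with a range of 40 nM to 1000 nM.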

Compound 4, half-maximal inhibitory concentration: 310 nM
Estimate against measurement, compound 4: 1.6-fold (0.19 log units) below; the measured number falls inside the stated range.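

In this assay, the change from diisobutylamino to isopropylamino on this saturated chain carbon gives a 6.1-fold lower number from compound 3 to compound 4 (0.79 log units; beyond the scatter). For the compounds shown here, this is the first single-place step, and it shows that the number at this position moves with the amine group alone, with no amide present. Even so, compound 4 at 310 nM stands above compound 1 at 28 nM; 29 nM (2 entries), which carries an acetyl group on the same isopropylamino nitrogen and whose repeated entries agree closely: the several entries of compound 1 in this assay, 28 nM; 29 nM (2 entries).

The one step changes heavy atoms and hydrogen-bond donors together, and the compounds shown do not separate the two. Going by these compounds, a dimethylamino group or an unsubstituted amino group at this place remains open, as does a longer chain on the nitrogen.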